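Amide substituent changes on the shared core

The source may hold more compounds than are shown below. What is called first, only, known or untested is meant among the compounds shown, and "the series" means these compounds.

Compound 1 `CCN(CC)CCNC(=O)c1ccc(C(CC)(CC)c2ccc(OCCC(O)(CC)CC)c(C)c2)n1CC` gives 2290 nM in an ADME assay on L02 cells (Homo sapiens) for antiproliferative activity, read by MTT assay, with a stated time of 48 h (a lower number here means a stronger inhibitor, a higher number a weaker inhibitor), the lowest of the two numbers in hand. Compound 2 `CCn1c(C(=O)NC(C)C(=O)O)ccc1C(CC)(CC)c1ccc(OCCC(O)(CC)CC)c(C)c1` gives 4040 nM, and the step of a 1.8-fold higher number from compound 1 to compound 2 (0.25 log units; within the scatter) stays within the scatter. Compound 3 `CCC(C)C(CO)NC(=O)c1ccc(C(CC)(CC)c2ccc(OCCC(O)(CC)CC)c(C)c2)n1CC` reaches only a limit of this assay, > 50000 nM. The steps of an at least 21-fold higher number from compound 1 to compound 3 (1.33 log units; beyond the scatter) and an at least 12-fold higher number from compound 2 to compound 3 (1.09 log units; beyond the scatter) both point towards a weaker inhibitor when the hydroxymethyl-bearing group enters. Compound 4 `CCn1c(C(=O)NC(CO)CCO)ccc1C(CC)(CC)c1ccc(OCCC(O)(CC)CC)c(C)c1` differs from compound 1 by 3-hydroxy-1-(hydroxymethyl)propyl in place of 2-(diethylamino)ethyl on an amide-type nitrogen. This change carries a hydroxymethyl group, as in the step of an at least 21-fold higher number from compound 1 to compound 3 (1.33 log units; beyond the scatter), rather than the carboxyethyl of a 1.8-fold higher number from compound 1 to compound 2 (0.25 log units; within the scatter), so a large rise of a 13-fold higher number from compound 1 to compound 4 (1.12 log units; beyond the scatter) is expected. Compound 4 is therefore estimated at 30000 nM, with a range from 7000 nM to 90000 nM, and a limit reading is possible.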

Compound 4, half-maximal inhibitory concentration: 3040 nM
Compound 4: the middle estimate sits 9.9-fold (0.99 log units) above what was measured; measured number below the stated range.
By their numbers in this assay, from the lowest: compounds 1, 4 and 2 (each within the scatter of the next). At a limit, above all of these: compound 3.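

Hydroxymethyl on the amide-type nitrogen substituent does not by itself go with a weaker inhibitor in this assay: compound 4 keeps the group, yet a 1.3-fold higher number from compound 1 to compound 4 (0.12 log units; within the scatter) and a 1.3-fold lower number from compound 2 to compound 4 (0.12 log units; within the scatter). The large step instead lies with 2-hydroxyethyl in place of sec-butyl on the saturated chain carbon, an at least 16-fold lower number from compound 3 to compound 4 (1.21 log units; beyond the scatter). Compound 3 gives a limit, not a number: the limit of > 50000 nM in this assay, at which 1 of the 4 values shown sits.

Still open, on these data alone, is how far sec-butyl alone accounts for that step. A phenyl ring or a longer unbranched alkyl chain on that carbon would bear on this.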